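The source may report more compounds than this note shows. Statements on the series, on what has been measured and on what is new or still open speak of the compounds shown alone.

Measured so far:
- Compound 1 `CC(/N=c1\c(O)c(O)\c1=N/c1cccnc1)C(C)(C)C`: 1950 nM
- Compound 2 `CC(C)(C)/N=c1\c(O)c(O)\c1=N/c1cccnc1Cl`: 1770 nM
- Compound 3 `CC(/N=c1\c(O)c(O)\c1=N/c1cnc2ccccc2c1)C(C)(C)C`: > 30000 nM

All three were tested in a functional assay for inhibition, with Rattus norvegicus as the target; on this read-out higher numbers stand for weaker inhibition and lower numbers for stronger inhibition. Compound 3 gives only a limit of the assay, not a number, and its reading is the limit of > 30000 nM in this assay, at which 1 of the 3 values shown sits.

Compound 4 `CC(C)(C)/N=c1\c(O)c(O)\c1=N/c1cnc2ccccc2c1` has not been measured yet. It differs from compound 3 in one place: tert-butyl in place of 1,2,2-trimethylpropyl on a double-bonded nitrogen.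

Among the compounds with values here, no two measured compounds differ in this group alone, so the size of this change has not been seen directly. Compound 1 carries 1,2,2-trimethylpropyl and gives 1950 nM, while compound 2 carries tert-butyl and gives 1770 nM, so both groups occur in compounds with real numbers. Only a small move towards stronger inhibition in this assay is expected, and the result may well stay at the limit. The expected step is an at least 1.5-fold lower number from compound 3 to compound 4 (0.17 log units; that floor lies within the scatter). For compound 4 the estimated value is 20000 nM, with an expected range of 6000 nM to 60000 nM.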

Compound 4, half-maximal inhibitory concentration: > 30000 nM
Compound 4: only a limit was reported; the forecaster's own chance of this, stated with the estimate: 55%; middle value at least 1.5-fold (0.17 log units) from the limit.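

Within the data shown here, compound 3 and compound 4 each gave only a limit of the assay, not a number, so no step between them can be read: the limit of > 30000 nM in this assay, at which 2 of the 4 values shown sit. The compounds shown leave open whether tert-butyl in place of 1,2,2-trimethylpropyl changes inhibition at all.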